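Cyanoguanidine series: aryl in place of benzyl on the guanidine

A few compounds are considered here, and "the series" means these few. Any claim that something is new, unique, unknown or untested is made for them only; others in the source may bear on it.

Compound 1 `CC1(C)Oc2ccc(C#N)cc2[C@@H](/N=C(\NC#N)NCc2ccccc2)[C@@H]1O` is the reference point of this pair. Among the measured compounds shown here, in a functional assay (aorta) with Rattus norvegicus as the target (on this read-out lower numbers stand for stronger inhibition and higher numbers for weaker inhibition), compound 1 gives 2400 nM, the lower of the two numbers measured so far. Compound 2 `CC1(C)Oc2ccc(C#N)cc2[C@@H](n2c(O)nc3ccccc32)[C@@H]1O`, which carries a different substituent on the shared core, gives in this assay 41000 nM; the gap from compound 1 to compound 2 lies well beyond the scatter of repeated runs, so compound 1 stands clearly as the more potent of the two.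

Compound 3 `COC(=O)c1ccc(N/C(=N/[C@@H]2c3cc(C#N)ccc3OC(C)(C)[C@H]2O)NC#N)cc1` keeps the core of compound 1 and the cyanoguanidine, and differs from compound 1 in one place: 4-(methoxycarbonyl)phenyl in place of benzyl on an amine nitrogen. For the measured compounds named here, no step between measured compounds covers this kind of exchange, so the direction is open. A step from compound 1 to compound 3 of moderate size, toward a weaker number, is expected, as a 1.9-fold higher number from compound 1 to compound 3 (0.27 log units; within the scatter), with a possibility that the change costs nothing beyond the scatter. Compound 3 is therefore estimated in this assay at 4500 nM, with a range from 1000 nM to 20000 nM.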

Compound 3, half-maximal inhibitory concentration: 18400 nM
Compound 3: the middle estimate sits 4.1-fold (0.61 log units) below what was measured, and the stated range covers the measured number.
By their numbers in this assay, from the lowest: compound 1; then compound 3; then compound 2.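

Placing 4-(methoxycarbonyl)phenyl in place of benzyl on the amine nitrogen of the cyanoguanidine is not a neutral exchange in this assay, as the series shows a 7.7-fold higher number from compound 1 to compound 3 (0.88 log units; beyond the scatter), a step beyond the scatter. Among the compounds shown here, this gives the first single-place reading for the series and shows that this nitrogen substituent affects the read-out, although compound 3 still gives a measurable 18400 nM. The step combines two changes, since benzyl gives way to a phenyl ring and a methoxycarbonyl group enters with it, and no measurement available here offers an explanation for the step.

Going by these compounds, whether the loss follows the change from benzyl to a phenyl ring or the methoxycarbonyl group remains open, and unsubstituted phenyl at this amine nitrogen would separate the two. Also open, on these data alone, is how a carboxylic acid or a primary amide in place of the methyl ester, or phenethyl as a longer chain in place of benzyl, would read in this assay.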